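Swapping Fluoro for Methoxy in Compound 3

A few compounds are considered here, and "the series" means these few. Any claim that something is new, unique, unknown or untested is made for them only; others in the source may bear on it.

In a functional assay on A549 cells (Homo sapiens) for cytotoxicity, read by WST assay, with a stated time of 24 h (a higher number here means a weaker inhibitor, a lower number a stronger inhibitor), compound 3 `N#C/C(=C\c1c[nH]c2cc(F)ccc12)C(=O)c1c[nH]c2ccccc12` gives 17000 nM. Compound 1 `COc1ccc2c(/C=C(\C#N)C(=O)c3c[nH]c4cc(F)ccc34)c[nH]c2c1`, at 10300 nM, lies within the scatter of that value, while compound 2 `COc1ccc2c(/C=C(\C#N)C(=O)c3c[nH]c4cc(OC)ccc34)c[nH]c2c1`, at 1900 nM, stands clearly lower. Compound 4 `COc1ccc2c(/C=C(\C#N)C(=O)c3c[nH]c4ccccc34)c[nH]c2c1` carries methoxy in place of fluoro on an aromatic carbon of compound 3: methoxy in place of fluoro on an aromatic carbon. For the measured compounds named here, one measured step bears on this, the same exchange made at a different place: a 5.4-fold lower number from compound 1 to compound 2 (0.73 log units; beyond the scatter). The data do not show whether that step carries over, so a modest drop of similar size is expected, with a wide margin. The expected change is a 4.9-fold lower number from compound 3 to compound 4 (0.69 log units; beyond the scatter). Compound 4 is estimated at 3500 nM, with an expected range of 1500 nM to 9000 nM.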

Compound 4, half-maximal inhibitory concentration: 9600 nM
Estimate against measurement, compound 4: 2.7-fold (0.44 log units) below, and the stated range ends below it.
By their numbers in this assay, from the lowest: compound 2; then compounds 4, 1 and 3 (each within the scatter of the next).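

In this assay, methoxy in place of fluoro does not have one size across the two cores: the same change on two cores in this assay, a 5.4-fold lower number (0.73 log units; beyond the scatter) from compound 1 to compound 2 and a 1.8-fold lower number (0.25 log units; within the scatter) from compound 3 to compound 4, 3.1-fold (0.49 log units) apart, beyond the scatter of two such steps. At this position the change gives a 1.8-fold lower number from compound 3 to compound 4 (0.25 log units; within the scatter), and at the other place, hydrogen in place of fluoro gives a 1.1-fold lower number from compound 1 to compound 4 (0.03 log units; within the scatter), so neither step leaves the scatter. Only removing the methoxy at that other place does, with hydrogen in its place giving a 5.1-fold higher number from compound 2 to compound 4 (0.70 log units; beyond the scatter).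

As far as these compounds go, whether an amine, a hydroxyl or an ethoxy group at this position would differ from methoxy stays open. So does whether the smaller step here depends on the group at the other place.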